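Replacing the 4-fluorobenzyl group of compound 1

This account rests on a few compounds, and the source may have more. Where it says the series, first, only, none or still open, it means among the compounds named here.

Measured so far in a functional assay on MDA-MB-231 cells (Homo sapiens) for inhibition, read by sulforhodamine B assay, with a stated time of 48 h; a higher number here means a weaker inhibitor, a lower number a stronger inhibitor:
- Compound 1 `COc1ccc(C(O)(Cc2ccc(F)cc2)c2cccc3ccccc23)c(OC)c1OC`: 5440 nM
- Compound 2 `CCOC(=O)/C=C/CO/N=C(/c1ccc(OC)c(OC)c1OC)c1cccc2ccccc12`: > 20000 nM (a limit of the assay, not a number)

Among the compounds with values here, compound 1 holds the only numerical value so far, at 5440 nM. Compound 2 reports only a limit, > 20000 nM.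

The next compound to be read is compound 3 `CCOC(=O)C(C)C(O)(c1ccc(OC)c(OC)c1OC)c1cccc2ccccc12`. It differs from compound 1 as follows: 1-(ethoxycarbonyl)ethyl in place of 4-fluorobenzyl on a saturated chain carbon bound to two aromatic carbons and an oxygen on a saturated carbon. In words, 1-(ethoxycarbonyl)ethyl stands in place of 4-fluorobenzyl on a saturated chain carbon bound to two aromatic carbons and an oxygen on a saturated carbon.

Within the data shown here, no measured step between compounds differing in one place is available, so the expectation rests on thin ground. Compound 2 also carries an ethoxycarbonyl group, and its result in this assay is the limit > 20000 nM. On that basis, a moderate shift towards weaker inhibition is expected, with a 2.2-fold higher number from compound 1 to compound 3 (0.34 log units; beyond the scatter) as the estimated step. A result that reaches the limit of this assay would not be surprising. For compound 3 the estimated value is 12000 nM, with an expected range of 4000 nM to 35000 nM.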

Compound 3, half-maximal inhibitory concentration: > 20000 nM
Compound 3: a limit, no number; the forecaster's own chance of this, stated with the estimate: 35%; at least 1.6-fold (0.22 log units) between middle value and limit.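

In this assay, within the data shown here, 1-(ethoxycarbonyl)ethyl in place of 4-fluorobenzyl on a saturated chain carbon bound to two aromatic carbons and an oxygen on a saturated carbon gives the only step that can be read so far, an at least 3.6-fold higher number from compound 1 to compound 3 (0.56 log units; beyond the scatter), so this position is not indifferent to the group it carries. The value of compound 3, > 20000 nM, is a limit of the assay and not a number. The size of the step is therefore known only as a lower bound, because the reading ends at the limit of the assay: the limit of > 20000 nM in this assay, at which 2 of the 3 values shown sit.

The change removes the six-membered aromatic ring of 4-fluorobenzyl and brings in the ester in a single step, and the compounds shown do not separate these two parts; an unsubstituted benzyl group, or a carboxylic acid or an amine in place of the ester, would bear on that question. They also leave open whether any group at this position can give a stronger inhibitor than compound 1, at 5440 nM.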